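Amide and Ester Cinnamoyl Stilbenes Against Colon Cancer Cells

The source may hold more compounds than are shown below. What is called first, only, known or untested is meant among the compounds shown, and "the series" means these compounds.

Compound 1 `COc1cc(/C=C/c2ccc(NC(=O)/C=C/c3ccc([N+](=O)[O-])cc3)cc2)cc(OC)c1` joins a cinnamoyl arm through an amide to a stilbene bearing two methoxy groups. In a functional assay on HT-29 cells (Homo sapiens) for inhibition, read by MTT assay, with a stated time of 48 h (a lower number here means a stronger inhibitor, a higher number a weaker inhibitor), compound 1 gives 10700 nM. Compound 2 `COc1cc(/C=C/c2ccc(NC(=O)/C=C/c3ccc(F)cc3)cc2)cc(OC)c1` differs from it in one place: fluoro in place of nitro on an aromatic carbon. In this assay compound 2 gives 11600 nM. The resulting step, a 1.1-fold higher number from compound 1 to compound 2 (0.04 log units; within the scatter), is small, so the two values are read as alike.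

Compound 3 `COc1cc(/C=C/c2ccc(OC(=O)/C=C/c3ccc([N+](=O)[O-])cc3)cc2)cc(OC)c1` links the same cinnamoyl arm through an ester instead. In this assay compound 3 reaches only a limit, > 20000 nM, which is the limit (the limit of > 20000 nM in this assay, at which 1 of the 3 values shown sits). The difference between the core of compound 3 and the core of compound 1 is not broken down here.

Compound 4 `COc1cc(/C=C/c2ccc(OC(=O)/C=C/c3ccc(F)cc3)cc2)cc(OC)c1` has not yet been measured. It differs from compound 3 by fluoro in place of nitro on an aromatic carbon, and the place of that change is described in the same words as for the change from compound 1 to compound 2, so it is the same change, made a second time. The step expected here, a step that the limit leaves unreadable from compound 3 to compound 4, rests on the measured 1.1-fold higher number from compound 1 to compound 2 (0.04 log units; within the scatter), which lay within the usual scatter. Since compound 3 sits at a limit, compound 4 is expected to give about 25000 nM in this assay, most likely again reported as a limit. The estimated range for compound 4 runs from 12000 nM to 60000 nM.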

Compound 4, half-maximal inhibitory concentration: 7770 nM
Compound 4: the middle estimate sits 3.2-fold (0.51 log units) above what was measured; the whole stated range lies above it.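

In this series, the change from 4-nitrophenyl to 4-fluorophenyl does not carry a single effect from one core to another, although two cores are a small basis for any wider rule. Compound 3 is recorded only at a limit of the assay (> 20000 nM). In this assay the ester pair therefore gives a step of known direction but open size (an at least 2.5-fold lower number from compound 3 to compound 4 (0.41 log units; beyond the scatter)), which shows that the fluoro compound on this core gives a lower number but does not show how large the full step is or why the core matters. Set against the amide pair, where the two values are alike, the result is a clear dependence on the core: the same change on two cores in this assay, a 1.1-fold higher number (0.04 log units; within the scatter) from compound 1 to compound 2 and an at least 2.5-fold lower number (0.41 log units; beyond the scatter) from compound 3 to compound 4, at least 2.7-fold (0.44 log units) apart, beyond the scatter of two such steps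

What the compounds shown leave open is whether this difference between the amide and ester cores holds for other groups in the same place on the ring, such as an amine or a carboxylic acid. They also leave open how a longer chain between the cinnamoyl arm and the rest of the molecule would affect the result on either core.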